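This account rests on a few compounds, and the source may have more. Where it says the series, first, only, none or still open, it means among the compounds named here.

Measured so far: compound 1 `CCC(=O)NCC1CCc2c(OC)cccc2N1C` gives 112% in a functional assay on CHO cells with melatonin receptor type 1A (Homo sapiens) as the target, read by GTPgammaS binding, with a stated time of 1 h; on this read-out higher numbers stand for larger maximal responses and lower numbers for smaller maximal responses; compound 2 `CCNC(=O)NCC1CCc2c(cccc2OC)N1` gives "not determined" (no result reported); compound 3 `CCC(=O)NCC1CCc2ccccc2N1` gives 37%.

Compound 3 holds the lowest of the two numbers in this assay; the nearest, compound 1, lies higher by a margin beyond the scatter, and compound 2 contributes no number. Within the data shown here, no two measured compounds differ in a single place, so no single-change step can be read off. Compound 4 `CCC(=O)NCC1CCc2c(cccc2OC)N1` is the next candidate; compared with compound 3 the change is methoxy in place of hydrogen on an aromatic carbon. The step from compound 3 to compound 4 is expected to be a number 48 percentage points higher from compound 3 to compound 4 (beyond the scatter), upward and beyond the scatter, because compound 1 gives 112% while carrying a methoxy among other differences. Compound 4 is accordingly estimated at 85%, with a range from 50% to 115%.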

Compound 4, largest response reached (Emax), in percent of the reference or control that the assay uses: 70%
Estimate against measurement, compound 4: 15 percentage points above; the range from low to high includes it.
By their numbers in this assay, from the lowest: compound 3; then compound 4; then compound 1.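

In this assay, methoxy in place of hydrogen on an aromatic carbon gives a number 33 percentage points higher from compound 3 to compound 4 (beyond the scatter) and shows that the maximal response changes with substitution at this position, at least in this pair. With the methoxy kept, hydrogen in place of methyl on the nitrogen gives a number 42 percentage points lower from compound 1 to compound 4 (beyond the scatter) and shows that this nitrogen substituent also changes the response. No measured evidence bears on the cause of either step.

From the compounds shown here alone, whether ethoxy or fluorine on the same aromatic carbon would give a similar response remains open. An ethyl group on the nitrogen is equally unresolved.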